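The source may hold more compounds than are shown below. What is called first, only, known or untested is meant among the compounds shown, and "the series" means these compounds.

Compound 1 `Cc1nc(N)c2c(-c3cccs3)cn([C@@H]3O[C@H](CO)[C@@H](O)[C@H]3O)c2n1`: > 20000 nM
Compound 2 `COc1nc(N)nc2c1c(-c1cccs1)cn2[C@@H]1O[C@H](CO)[C@@H](O)[C@H]1O`: > 20000 nM

In a functional assay on K562 cells (Homo sapiens), read by MTT assay, with a stated time of 72 h (a lower number here means a stronger inhibitor, a higher number a weaker inhibitor), compound 1 gives > 20000 nM, which is a limit of the assay rather than a number. Compound 2 gives > 20000 nM in the same assay, again only a limit. Both entries therefore sit at the limit of > 20000 nM in this assay, at which 2 of the 2 values shown sit, and compound 2 stands nowhere more definite than that. Compound 3 `Nc1nc(N)c2c(-c3cccs3)cn([C@@H]3O[C@H](CO)[C@@H](O)[C@H]3O)c2n1` differs from compound 2 by amino in place of methoxy on an aromatic carbon. For the measured compounds named here, with no measured step available between any two compounds, the expected step is none beyond the scatter, so the estimate is a step that the limit leaves unreadable from compound 2 to compound 3. Compound 3 is thus expected at 30000 nM, within 8000 nM to 100000 nM, most likely reported again only as a limit.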

Compound 3, half-maximal inhibitory concentration: > 20000 nM
Compound 3: no number, only a limit (the forecaster's own chance of this, stated with the estimate: 80%); the middle value does not contradict the limit.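

Compound 1, compound 2 and compound 3 each give only a limit in this assay, so no step between them can be read: the limit of > 20000 nM in this assay, at which 3 of the 3 values shown sit.

On these data alone, how strongly each inhibits, and whether methyl, methoxy or amino on that aromatic carbon makes any difference, stays open.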